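Adding a methyl to the thiazole of compound 1

The source may report more compounds than this note shows. Statements on the series, on what has been measured and on what is new or still open speak of the compounds shown alone.

Compound 1 `O=C(Cn1cc(-c2ccc([N+](=O)[O-])cc2)nn1)Nc1nccs1` gives 1040 nM in a functional assay on BMDM cells (Mus musculus, strain C57BL/6) for inhibition, with a stated time of 2 days (on this read-out lower numbers stand for stronger inhibition and higher numbers for weaker inhibition), the higher of the two numbers that are not limits. Compound 3 `O=C(Cn1cc(-c2ccc(F)cc2)nn1)Nc1nccs1` gives 190 nM in this assay, a 5.5-fold lower number from compound 1 to compound 3 (0.74 log units; beyond the scatter). Compound 2 `C#Cc1ccc(-c2cn(CC(=O)Nc3nccs3)nn2)cc1` yields in this assay only a limit, > 30000 nM. From it, an at least 28-fold higher number from compound 1 to compound 2 (1.46 log units; beyond the scatter) and an at least 150-fold lower number from compound 2 to compound 3 (2.19 log units; beyond the scatter). Compound 4 `Cc1csc(NC(=O)Cn2cc(-c3ccc([N+](=O)[O-])cc3)nn2)n1` differs from compound 1 thus: methyl in place of hydrogen on an aromatic carbon. All three measured steps replace the nitro group of compound 1 on its phenyl ring; none alters the 1,3-thiazol-2-yl side, so none bears directly on this change. Compound 4 is therefore expected to sit close to compound 1, with a 1.0-fold lower number from compound 1 to compound 4 (0.02 log units; within the scatter) expected to stay within the scatter, around 1000 nM in this assay, between 350 nM and 3000 nM.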

Compound 4, half-maximal inhibitory concentration: 190 nM
For compound 4 the middle estimate is 5.3-fold (0.72 log units) above the measured one; measured number below the stated range.
By their numbers in this assay, from the lowest: compounds 3 and 4 (each within the scatter of the next); then compound 1. At a limit, above all of these: compound 2.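

In this assay, going by these compounds alone, the 1,3-thiazol-2-yl side of the core also governs the read-out, which the earlier steps, all made on the phenyl ring, could not show: methyl in place of hydrogen gives a 5.5-fold lower number from compound 1 to compound 4 (0.74 log units; beyond the scatter). A single carbon, placed on the aromatic carbon next to the ring nitrogen, is thus enough for a step beyond the scatter. Nothing measured here accounts for this step.

From the compounds shown here alone, whether the same methyl would also lower the number when fluoro replaces nitro on the phenyl ring remains open. So does the effect of an ethyl group or an amine on this carbon.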